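Acetylating the amino group of compound 3

The compounds below may be only part of what the source reports. "The series", "measured", "known", "first", "only" and "open" are said of these compounds alone.

In a functional assay on P388 cells (Mus musculus) for inhibition (a lower number here means a stronger inhibitor, a higher number a weaker inhibitor), compound 1 `COc1ccc(/C=C\c2ccc3ccccc3c2)cc1N` gives 1820 nM, and compound 3 `COc1cc(/C=C\c2ccc3ccccc3c2)cc(N)c1OC` gives 1640 nM. Compound 2 `COc1cc(/C=C/c2ccc3c(ccn3S(=O)(=O)c3ccccc3)c2)cc(OC)c1OC` returns only a limit, > 5000 nM, in this assay. For the measured compounds named here, the one measured step, a 1.1-fold lower number from compound 1 to compound 3 (0.05 log units; within the scatter), places methoxy in place of hydrogen on an aromatic carbon and leaves the two numbers level, so compound 3 stands with compound 1 as one of only two actual numbers.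

Compound 4 `COc1cc(/C=C\c2ccc3ccccc3c2)cc(NC(C)=O)c1OC` differs from compound 3 by acetyl in place of hydrogen on a nitrogen on an aromatic ring, or amino to acetamido. Going by the values given here, no measured step touches that nitrogen, and the methoxy step gives no size for this change. Compound 1 and compound 3 both carry the free amino group, while compound 2 lacks it but differs in much else, so the hint is weak. A move toward a higher number in this assay is tentatively expected, starting from compound 3 at 1640 nM. Such a move could approach (the limit of > 5000 nM in this assay, at which 1 of the 3 values shown sits). The expected size is a 2.1-fold higher number from compound 3 to compound 4 (0.33 log units; beyond the scatter). Compound 4 is estimated at 3500 nM, with an expected range of 1400 nM to 9000 nM.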

Compound 4, half-maximal inhibitory concentration: > 5000 nM
Compound 4 gave a limit, no number; the forecaster's own chance of this, stated with the estimate: 35%; at least 1.4-fold (0.15 log units) between middle value and limit.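

In this assay, the nitrogen on the aromatic ring now has a measured step of its own: acetyl in place of hydrogen, or amino to acetamido, gives an at least 3.0-fold higher number from compound 3 to compound 4 (0.48 log units; beyond the scatter) and so lies beyond the scatter, whereas the earlier step, methoxy in place of hydrogen on an aromatic carbon, left the two numbers level. Compound 4 gives > 5000 nM, which is a limit and not a number, so the step sets only a lower bound on the size of this change. This position therefore does not tolerate every change: a single acetyl on this nitrogen takes the series from an actual number to the limit, and the count of compounds there rises: the limit of > 5000 nM in this assay, at which 2 of the 4 values shown sit.

Going by these compounds, how far compound 4 lies past the limit stays unknown, and a single acyl group cannot show whether the loss follows from acylation in general or from acetyl alone. Also open, on these data alone, is whether a methyl group or a methanesulfonyl group on this nitrogen, or a hydroxyl group in place of the amino group, would keep an actual number in this assay as compound 3 does.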